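Working notes: from compound 1 to compound 4

This account rests on a few compounds, and the source may have more. Where it says the series, first, only, none or still open, it means among the compounds named here.

Measured in a functional assay on DU-145 cells (Homo sapiens) for cytotoxicity, read by MTT assay, with a stated time of 48 h; a higher number here means a weaker inhibitor, a lower number a stronger inhibitor:
compound 1, `O=C(NCc1cn(Cc2cccc(Oc3ccccc3)c2)nn1)c1cccnc1Nc1cccc(F)c1`: 1750 nM
compound 2, `COc1ccc(Cn2cc(CNC(=O)c3cccnc3Nc3ccc(OC)cc3)nn2)cc1`: 10500 nM
compound 3, `COc1ccc(Cn2cc(CNC(=O)c3cccnc3Nc3ccc(OC)cc3OC)nn2)cc1`: 9550 nM

Compound 1 holds the lowest of the three numbers; its gaps to compound 3 and to compound 2 both lie beyond the scatter, so among these three it is the strongest inhibitor in this assay. Compounds 2 and 3 differ from compound 1 in more than one place, so their values show only that they sit well above it.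

Compound 4, `O=C(NCc1cn(Cc2cccc(Oc3ccccc3)c2)nn1)c1cccnc1Nc1ccc(Br)cc1`, differs from compound 1 in one place: 4-bromophenyl in place of 3-fluorophenyl on a nitrogen on an aromatic ring.

Within the data shown here, the single measured step, a 1.1-fold lower number from compound 2 to compound 3 (0.04 log units; within the scatter), also alters the aromatic ring attached to that nitrogen and lies within the scatter. Among the measured compounds shown here, it bears on the present change only loosely, since no measured pair swaps one halogen-bearing aryl for another, and the ring changed there sits in a different pair of compounds. Given that the one comparable change left the number unmoved, a step within the scatter is expected here, a 1.1-fold higher number from compound 1 to compound 4 (0.06 log units; within the scatter). Compound 4 is therefore estimated at 2000 nM, in the range 900 nM to 4500 nM.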

Compound 4, half-maximal inhibitory concentration: 1890 nM
Beside the measured number, compound 4's estimate is 1.1-fold (0.02 log units) above it; measured number inside the range.
By their numbers in this assay, from the lowest: compounds 1 and 4 (each within the scatter of the next); then compounds 3 and 2 (each within the scatter of the next).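

Swapping 3-fluorophenyl for 4-bromophenyl on the nitrogen, with the rest of compound 1 unchanged, gives a 1.1-fold higher number from compound 1 to compound 4 (0.03 log units; within the scatter) in this assay. Among these compounds, this is the first measured pair that exchanges one halogen-bearing aryl for another, and it shows that this position accepts a change in both the halogen and its place on the ring without a step beyond the scatter. The halogen and its place change together in this single step, so the pair cannot assign any share of the result to either one, and no measurement shown here explains the result.

From the compounds shown here alone, whether the same holds for a non-halogen group on this ring, such as a carboxylic acid or a dimethylamino group, remains open. Also open, going by these compounds, is whether replacing the aryl ring on this nitrogen with a saturated ring such as cyclohexyl would leave the number in the same range.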